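Cyclohexyloxy in Place of Cyclopentyl: One Predicted Step

The source may hold more compounds than are shown below. What is called first, only, known or untested is meant among the compounds shown, and "the series" means these compounds.

Three compounds share one core and differ only in the group attached to the carbonyl carbon at the far end. Compound 1 `CCNC(=O)Nc1sc2ccccc2c1C(=O)N1CCN(C2CCN(C(=O)C(C)C)CC2)CC1` carries an isopropyl there, and in a functional assay on HepG2 cells (Homo sapiens) for inhibition, read by scintillation counting, with a stated time of 2 h (on this read-out lower numbers stand for stronger inhibition and higher numbers for weaker inhibition), compound 1 gives "not determined" (no result reported), so no number for it has been reported. For the measured compounds named here, compound 2 `CCNC(=O)Nc1sc2ccccc2c1C(=O)N1CCN(C2CCN(C(=O)C3CCCC3)CC2)CC1` carries a cyclopentyl, and in this assay compound 2 gives 309 nM; this is the only number available, so it stands alone as the reference point for the series.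

Compound 3 `CCNC(=O)Nc1sc2ccccc2c1C(=O)N1CCN(C2CCN(C(=O)OC3CCCCC3)CC2)CC1` is the one still to be tested. It differs from compound 2 by cyclohexyloxy in place of cyclopentyl on a carbonyl carbon. Going by the values given here, no measured pair shows how such a change plays out, so the expectation rests on compound 2 alone. The step of a 1.0-fold higher number from compound 2 to compound 3 (0.02 log units; within the scatter) is expected to stay within the usual scatter, with no clear direction. Compound 3 is therefore expected to give about 320 nM in this assay, somewhere between 110 nM and 950 nM.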

Compound 3, half-maximal inhibitory concentration: 635 nM
The estimate for compound 3 lay 2.0-fold (0.30 log units) below the measured number; the measured number falls inside the stated range.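

Replacing cyclopentyl with cyclohexyloxy on a carbonyl carbon attached to an amide-type nitrogen in a ring gives a 2.1-fold higher number from compound 2 to compound 3 (0.31 log units; beyond the scatter) in this assay. This shows that the position responds to the change, with modestly weaker inhibition for compound 3. The swap alters two things at once, enlarging the carbon ring from five-membered to six-membered and adding an oxygen that counts as one hydrogen-bond acceptor, and no measurement available here explains the step.

This single pair leaves open whether the oxygen or the larger ring matters more: cyclopentyloxy or cyclohexyl on the same carbonyl carbon would separate the two. From the compounds shown here alone, compound 1 carries an isopropyl but has no number for comparison, so the effect of a smaller open-chain group also remains unknown.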